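The source may hold more compounds than are shown below. What is called first, only, known or untested is meant among the compounds shown, and "the series" means these compounds.

Three compounds have been measured in a functional assay on HT-29 cells (Homo sapiens) for cytotoxicity, read by MTT assay, with a stated time of 72 h; a higher number here means a weaker inhibitor, a lower number a stronger inhibitor:

compound 1 `COc1ccc(/C=C/C(=O)Nc2cc(C(=O)c3cc(OC)c(OC)c(OC)c3)ccc2OC)cc1`: 5010 nM
compound 2 `COc1ccc(C(=O)c2cc(OC)c(OC)c(OC)c2)cc1NC(=O)/C=C/c1cccc(OC(F)(F)F)c1`: 5200 nM
compound 3 `COc1ccc(/C=C/C(=O)Nc2cc(C(=O)c3cc(OC)c(OC)c(OC)c3)cc(OC)c2OC)cc1`: 3800 nM

Compound 3 carries the lowest of the three numbers, yet its nearest neighbour is compound 1, and the step of a 1.3-fold lower number from compound 1 to compound 3 (0.12 log units; within the scatter) lies within the scatter; the gap to compound 2 is of the same order, so no ranking among the three can be drawn from these values.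

Compound 4 `COc1cc(C(=O)c2cc(OC)c(OC)c(OC)c2)cc(NC(=O)/C=C/c2ccc(F)cc2)c1OC` differs from compound 3 in one place: fluoro in place of methoxy on an aromatic carbon. The change sits on the phenyl ring at the end of the ethenyl chain, the same ring that was altered between compound 1 and compound 2. That step, a 1.0-fold higher number from compound 1 to compound 2 (0.02 log units; within the scatter), replaced 4-methoxyphenyl with 3-(trifluoromethoxy)phenyl and left the number essentially unmoved. The other step, a 1.3-fold lower number from compound 1 to compound 3 (0.12 log units; within the scatter), concerns a methoxy on the other aromatic ring and is also within the scatter. Among the compounds with values here, with the only comparable change on this ring giving no shift, the expectation for compound 4 is a step of a 1.1-fold higher number from compound 3 to compound 4 (0.02 log units; within the scatter), that is, no movement beyond the scatter in either direction. Compound 4 is therefore estimated at 4000 nM, with a range from 1500 nM to 11000 nM.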

Compound 4, half-maximal inhibitory concentration: 1800 nM
Beside the measured number, compound 4's estimate is 2.2-fold (0.35 log units) above it; measured number inside the range.
By their numbers in this assay, from the lowest: compound 4; then compounds 3, 1 and 2 (each within the scatter of the next).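

In this assay, within the data shown here, a 2.1-fold lower number from compound 3 to compound 4 (0.32 log units; beyond the scatter) is the first step in this set to lie beyond the scatter, and it comes from 4-fluorophenyl in place of 4-methoxyphenyl at the end of the ethenyl chain, a change on an aromatic carbon para to a large group. The number on this ring is therefore not insensitive to substitution, as the earlier step of a 1.0-fold higher number from compound 1 to compound 2 (0.02 log units; within the scatter) alone might have suggested: that step, 3-(trifluoromethoxy)phenyl in place of 4-methoxyphenyl, altered both the group and its place on the ring and stayed within the scatter, whereas fluoro in place of methoxy at the same place gives a modest but readable shift. Nothing available here bears on why this exchange moves the number.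

The compounds shown leave open whether the step holds without the extra methoxy that sets compound 3 apart from compound 1, as fluoro appears here only on the core of compound 3. They also leave open whether fluoro itself or the loss of methoxy counts, which hydrogen, chloro or trifluoromethyl at this place would help to separate.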